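The source may report more compounds than this note shows. Statements on the series, on what has been measured and on what is new or still open speak of the compounds shown alone.

Working notes on the series, shared core as drawn in compound 1 `C=C1CC[C@@H]2[C@](C)(COC(C)=O)[C@H](OC(C)=O)CC[C@@]2(C)[C@H]1CC(Nc1ccc(S(=O)(=O)Nc2nccs2)cc1)C1=CCOC1=O`. Within the data shown here, in a functional assay on LOX IMVI cells (Homo sapiens) for inhibition, read by sulforhodamine B assay, with a stated time of 48 h (on this read-out lower numbers stand for stronger inhibition of growth and higher numbers for weaker inhibition of growth), compound 1 gives 1590 nM, the highest of the three numbers measured so far. Compound 2 `C=C1CC[C@@H]2[C@](C)(COC(C)=O)[C@H](OC(C)=O)CC[C@@]2(C)[C@H]1CC(Nc1ccc(S(=O)(=O)Nc2ccc(Cl)nn2)cc1)C1=CCOC1=O` gives 290 nM in this assay, and compound 3 `C=C1CC[C@@H]2[C@](C)(COC(C)=O)[C@H](OC(C)=O)CC[C@@]2(C)[C@H]1CC(Nc1ccc(S(=O)(=O)Nc2ncccn2)cc1)C1=CCOC1=O` gives 890 nM. The step of a 5.5-fold lower number from compound 1 to compound 2 (0.74 log units; beyond the scatter) is beyond the scatter; the step of a 1.8-fold lower number from compound 1 to compound 3 (0.25 log units; within the scatter) is within it, so compound 1 and compound 3 cannot be ordered on these numbers. The step of a 3.1-fold higher number from compound 2 to compound 3 (0.49 log units; beyond the scatter) is again beyond the scatter.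

Compound 4 `C=C1CC[C@@H]2[C@](C)(COC(C)=O)[C@H](OC(C)=O)CC[C@@]2(C)[C@H]1CC(Nc1ccc(S(=O)(=O)Nc2cc(C)on2)cc1)C1=CCOC1=O` has not yet been measured in this assay. Its change from compound 1 is 5-methyl-1,2-oxazol-3-yl in place of 1,3-thiazol-2-yl on a sulfonamide nitrogen. Among the measured compounds shown here, no measured step makes this same exchange; the two that bear on it are the other exchanges on the sulfonamide nitrogen from compound 1, one modest and one within the scatter, both toward lower numbers. The entering group is another five-membered aromatic ring with two hetero atoms, the closest analogy among the measured steps being the within-scatter one to compound 3. The step of a 1.6-fold lower number from compound 1 to compound 4 (0.20 log units; within the scatter) is therefore expected to be small, leaning toward a lower number but possibly not beyond the scatter. Compound 4 is estimated to give 1000 nM in this assay, with an expected range from 350 nM to 3000 nM.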

Compound 4, concentration for 50% growth inhibition: 1180 nM
For compound 4 the middle estimate is 1.2-fold (0.07 log units) below the measured one; measured number inside the range.
By their numbers in this assay, from the lowest: compound 2; then compounds 3, 4 and 1 (each within the scatter of the next).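

In this assay, the new ring on the sulfonamide nitrogen gives a 1.3-fold lower number from compound 1 to compound 4 (0.13 log units; within the scatter) and a 1.3-fold higher number from compound 3 to compound 4 (0.12 log units; within the scatter) as its two steps, so compound 1, compound 3 and compound 4 cannot be ordered on these numbers, and 5-methyl-1,2-oxazol-3-yl is not separated from either 1,3-thiazol-2-yl or pyrimidin-2-yl. Against the same series, the step of a 4.1-fold higher number from compound 2 to compound 4 (0.61 log units; beyond the scatter) adds a third comparison beyond the scatter for compound 2, which now stands as the strongest of the four, and the only departure at this position rests on 6-chloropyridazin-3-yl alone. Nothing measured here accounts for these steps, so the separation of compound 2 stays an observation without an explanation.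

The compounds shown leave open whether that separation belongs to the chlorine or to the pyridazin-3-yl ring, a question that a pyridazin-3-yl carrying methoxy or a methyl group in place of chlorine would address. Also open, as far as these compounds go, is whether the methyl group of compound 4 matters at all, which the plain 1,2-oxazol-3-yl ring would test.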